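From 6-methoxypyridin-3-yl to 6-methylpyridin-3-yl

The source may report more compounds than this note shows. Statements on the series, on what has been measured and on what is new or still open speak of the compounds shown alone.

Measured so far in a functional assay on HepG2 cells (Homo sapiens) for inhibition, read by MTT assay, with a stated time of 48 h; a lower number here means a stronger inhibitor of growth, a higher number a weaker inhibitor of growth
compound 1 (`Cn1cc(C2CC(c3ccccc3)=NN2C(=O)c2cccnc2)c2ccccc21`) gives 4630 nM
compound 2 (`Cn1cc(C2CC(c3ccccc3)=NN2C(=O)c2ccc(Cl)nc2)c2ccccc21`) gives 7910 nM
compound 3 (`COc1ccc(C(=O)N2N=C(c3ccccc3)CC2c2cn(C)c3ccccc23)cn1`) gives 3130 nM

Two steps place the methoxy compound: a 1.5-fold lower number from compound 1 to compound 3 (0.17 log units; within the scatter) and a 2.5-fold lower number from compound 2 to compound 3 (0.40 log units; beyond the scatter). Compound 3 therefore stands level with compound 1 and apart from compound 2 only.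

Compound 4 (`Cc1ccc(C(=O)N2N=C(c3ccccc3)CC2c2cn(C)c3ccccc23)cn1`) carries methyl in place of methoxy on an aromatic carbon, next to the ring nitrogen and para to a large group (methyl in place of methoxy on an aromatic carbon). Among the compounds with values here, no measured step has methyl at this place, so the evidence is indirect. The remaining step, a 1.7-fold higher number from compound 1 to compound 2 (0.23 log units; within the scatter), also shows little separation among these substituents. The closest guide is a 1.5-fold lower number from compound 1 to compound 3 (0.17 log units; within the scatter), which suggests a value near that of compound 1 at 4630 nM once methoxy leaves.

The expected change is small and toward a higher number, and the estimated step is a 1.4-fold higher number from compound 3 to compound 4 (0.14 log units; within the scatter). In this assay the estimate for compound 4 is 4300 nM, with an expected range from 2300 nM to 8000 nM.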

Compound 4, concentration for 50% growth inhibition: 1220 nM
Estimate against measurement, compound 4: 3.5-fold (0.55 log units) above, and the stated range ends above it.
By their numbers in this assay, from the lowest: compound 4; then compounds 3, 1 and 2 (each within the scatter of the next, the first and the last beyond it).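

Methyl is the first group at this position in this assay to separate a compound from compound 1, which has hydrogen there (a 3.8-fold lower number from compound 1 to compound 4 (0.58 log units; beyond the scatter)); chloro and methoxy each stayed within the scatter of hydrogen. Methyl also stands apart from both of those groups, from methoxy (a 2.6-fold lower number from compound 3 to compound 4 (0.41 log units; beyond the scatter)) and from chloro (a 6.5-fold lower number from compound 2 to compound 4 (0.81 log units; beyond the scatter)), the latter being the widest step in the set, so the position responds to the group it carries even though a swap that removes a single heavy atom is a small one. Nothing measured in this set accounts for the difference between methyl and methoxy.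

From the compounds shown here alone, whether the lower number is specific to methyl remains open, as an ethyl group, a longer chain or trifluoromethyl at this place would be needed to test it. An amine or a carboxylic acid here would show whether the position tolerates groups of a different kind.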